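Swapping the Aryl on the Ring Nitrogen of Compound 1

The source may hold more compounds than are shown below. What is called first, only, known or untested is meant among the compounds shown, and "the series" means these compounds.

Measured so far:
compound 1 `Cc1cccc(N2C(=O)CSC2c2cccc(C(=O)NCCCCc3ccccc3)c2)c1`: 84%
compound 2 `O=C(NCCCCc1ccccc1)c1cccc(C2OCC(=O)N2c2cccc(F)c2)c1`: 32%

In a functional assay on SJSA-1 cells (Homo sapiens) for inhibition, read by CCK-8 assay, with a stated time of 72 h, tested at 1 uM (on this read-out higher numbers stand for more inhibition at the one concentration tested (going by the name of the read-out) and lower numbers for less inhibition), compound 1 gives 84%, the highest of the two numbers. For the measured compounds named here, compound 2 gives 32%, a gap beyond the scatter, but the two structures differ in more than one place, so no single step can be drawn from them. Compound 3 `COc1c(F)cccc1N1C(=O)CSC1c1cccc(C(=O)NCCCCc2ccccc2)c1` is not yet measured. It differs from compound 1 in one place: 3-fluoro-2-methoxyphenyl in place of 3-methylphenyl on an amide-type nitrogen in a ring. Going by the values given here, no measured step covers this change; a modest downward step, a number 12 percentage points lower from compound 1 to compound 3 (beyond the scatter), is expected, within or near the scatter. Compound 3 is therefore estimated at 72%, ranging from 45% to 92%.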

Compound 3, a percentage reported as inhibition, at one concentration (the size of the read-out at that concentration, not a potency): 1%
The estimate for compound 3 lay 71 percentage points above the measured number, and the stated range ends above it.
By their numbers in this assay, from the lowest: compound 3; then compound 2; then compound 1.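

On the amide-type nitrogen in the ring, the choice of aryl decides the outcome in this assay: 3-fluoro-2-methoxyphenyl in place of 3-methylphenyl gives a number 83 percentage points lower from compound 1 to compound 3 (beyond the scatter) and leaves almost no inhibition. Compound 1 and compound 2 could not show this, as they differ in more than one place. Nothing at hand accounts for the drop. Still open, as far as these compounds go, is whether the methoxy or the fluorine alone carries the step, and how an unsubstituted phenyl or a pyridine would read at this position.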